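Swapping dimethylamino for piperidin-1-yl in compound 4

The source may hold more compounds than are shown below. What is called first, only, known or untested is meant among the compounds shown, and "the series" means these compounds.

In an ADME assay on SH-SY5Y cells (Homo sapiens) for cytotoxicity, read by MTT assay, with a stated time of 48 h (a lower number here means that less compound is needed, a higher number that more compound is needed for the effect), compound 1 `O=C(O)c1ccc(-c2ccccc2C(=O)NCCCCCCCn2cc(-c3cccnc3)nn2)cc1` gives 224 nM, compound 2 `O=C(NCCCCCCCn1cc(-c2cccnc2)nn1)c1ccccc1-c1cccnc1` gives 36.5 nM and compound 3 `CN(C)Cc1cn(-c2ccccc2C(=O)NCCCCCCCn2cc(-c3cccnc3)nn2)nn1` gives 285 nM. The step of a 1.3-fold higher number from compound 1 to compound 3 (0.10 log units; within the scatter) lies within the usual scatter, so those two cannot be told apart, while the step of a 7.8-fold higher number from compound 2 to compound 3 (0.89 log units; beyond the scatter) goes beyond it.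

Compound 4 `O=C(NCCCCCCCn1cc(-c2cccnc2)nn1)c1ccccc1-n1cc(CN2CCCCC2)nn1` has piperidin-1-yl in place of dimethylamino on a saturated chain carbon bound to an aromatic carbon. For the measured compounds named here, no measured step makes this exact swap. The closest evidence is the step of a 7.8-fold higher number from compound 2 to compound 3 (0.89 log units; beyond the scatter), which exchanges a whole group on an aromatic carbon, and the step of a 1.3-fold higher number from compound 1 to compound 3 (0.10 log units; within the scatter), which does the same and stays within the scatter. The change here is smaller. The triazole and its methyl link remain in place. No step beyond the scatter is therefore expected in this assay. The estimated step of a 1.2-fold lower number from compound 3 to compound 4 (0.09 log units; within the scatter) is small and slightly downward, though its direction is uncertain. Compound 4 is expected at 230 nM, within a range of 90 nM to 560 nM.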

Compound 4, half-maximal effective concentration: > 500 nM
Compound 4: no number, only a limit; the forecaster's own chance of this, stated with the estimate: 3%; middle value at least 2.1-fold (0.33 log units) away from the limit.
By their numbers in this assay, from the lowest: compound 2; then compounds 1 and 3 (each within the scatter of the next). At a limit, above all of these: compound 4.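

In this assay compound 4 gives no number, only a limit: the limit of > 500 nM in this assay, at which 1 of the 4 values shown sits.

Placing piperidin-1-yl for dimethylamino on the saturated chain carbon gives an at least 1.7-fold higher number from compound 3 to compound 4 (0.24 log units; that floor lies within the scatter), and as that floor lies within the scatter, this swap alone is not shown to raise the number. Even so, this triazole-bearing compound separates from both other cores, with an at least 2.2-fold higher number from compound 1 to compound 4 (0.34 log units; beyond the scatter) and an at least 13-fold higher number from compound 2 to compound 4 (1.13 log units; beyond the scatter), whereas its dimethylamino partner could not be told apart from compound 1, with a 1.3-fold higher number from compound 1 to compound 3 (0.10 log units; within the scatter).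

Going by these compounds, the true size of the swap remains open, since only a floor can be read for it. Also open, on these data alone, is whether a smaller ring such as pyrrolidin-1-yl, or a ring with a second hetero atom such as morpholin-4-yl, would sit nearer to compound 3 or to compound 4.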